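The compounds below may be only part of what the source reports. "The series", "measured", "known", "first", "only" and "open" are said of these compounds alone.

Values from a functional assay on HCT-116 cells (Homo sapiens) for antiproliferative activity, read by CCK-8 assay, with a stated time of 72 h (on this read-out lower numbers stand for stronger inhibition and higher numbers for weaker inhibition), follow.
compound 1 `CCOc1cc(C(C)(C)C)ccc1C1=NC(c2ccc(Cl)cc2)C(c2ccc(Cl)cc2)N1C(=O)N1CCN(CCCCCC(=O)NO)CC1` gives 4030 nM
compound 2 `CCOc1cc(C(C)(C)C)ccc1C1=NC(c2ccc(Cl)cc2)C(c2ccc(Cl)cc2)N1C(=O)N1CCN(Cc2ccc(C(=O)NO)cc2)CC1` gives 2030 nM

Compound 2 has a single measured neighbour, and a 2.0-fold lower number from compound 1 to compound 2 (0.30 log units; within the scatter) means the two cannot be told apart. Compound 3 `CCOc1cc(C(C)(C)C)ccc1C1=NC(c2ccc(Cl)cc2)C(c2ccc(Cl)cc2)N1C(=O)N1CCN(CCCCC(=O)NO)CC1` carries 3-(hydroxycarbamoyl)propyl in place of 4-(hydroxycarbamoyl)phenyl on a saturated chain carbon bound to an amine nitrogen in a ring. Among the compounds with values here, that one measured step exchanged 4-(hydroxycarbamoyl)butyl for 4-(hydroxycarbamoyl)phenyl at this place, and no measurement yet tests the shorter chain. Little change is expected in this assay for this swap, with an estimated 1.6-fold higher number from compound 2 to compound 3 (0.20 log units; within the scatter) and nothing beyond the scatter. The estimate for compound 3 is 3200 nM (expected range 1300 nM to 8000 nM).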

Compound 3, half-maximal inhibitory concentration: 5210 nM
Beside the measured number, compound 3's estimate is 1.6-fold (0.21 log units) below it; the range from low to high includes it.
By their numbers in this assay, from the lowest: compounds 2, 1 and 3 (each within the scatter of the next, the first and the last beyond it).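

In this assay, within the data shown here, the 3-(hydroxycarbamoyl)propyl chain can now be told apart from the 4-(hydroxycarbamoyl)phenyl group, with a 2.6-fold higher number from compound 2 to compound 3 (0.41 log units; beyond the scatter), the first step at this position to pass the scatter, though only modestly. Between the two chains, a 1.3-fold higher number from compound 1 to compound 3 (0.11 log units; within the scatter) shows no difference that can be read, so this change in chain length does not register here. Nothing available gives a reason for these results. Still open, from the compounds shown here alone, is whether a longer chain, or a carboxylic acid in place of the hydroxycarbamoyl group, would shift the number in this assay.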